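The compounds below may be only part of what the source reports. "The series", "measured", "known", "first", "only" and "open" are said of these compounds alone.

Working notes on the series. Compound 1 `Cc1c2c(n3c1CCCNC[C@H](C)Nc1cc-3ccc1C(N)=O)CC(C)(C)CC2=O` is the parent of the set and carries a hydrogen on an amine nitrogen in a ring. In a physicochemical assay for solubility (a higher number here means a more soluble compound, a lower number a less soluble compound), compound 1 gives > 100 ug/mL, which is a limit of the assay and not a number. Compound 2 `CC(=O)NCCN1CC[C@H](C)Nc2cc(ccc2C(N)=O)-n2c(c(C)c3c2CC(C)(C)CC3=O)CC1=O` gives > 100 ug/mL in this assay, again a limit. Compound 3 `Cc1c2c(n3c1CCCN(CCN)C(=O)[C@H](C)Nc1cc-3ccc1C(N)=O)CC(C)(C)CC2=O` gives > 100 ug/mL in this assay, also a limit. Within the data shown here, the whole measured set therefore sits at the limit of > 100 ug/mL in this assay, at which 3 of the 3 values shown sit, so compound 1 cannot be placed above or below the two others, and no step between measured compounds can be stated.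

Compound 4 `CC(=O)N1CCCc2c(C)c3c(n2-c2ccc(C(N)=O)c(c2)N[C@@H](C)C1)CC(C)(C)CC3=O` differs from compound 1 in one place: acetyl in place of hydrogen on an amine nitrogen in a ring. Among the measured compounds shown here, no measured pair in the set shows a change of this kind, so the expectation rests only on the three limits and the nature of the change. The step from compound 1 to compound 4 is expected to be a modest decrease, an at least 1.4-fold lower number from compound 1 to compound 4 (0.15 log units; that floor lies within the scatter), which may or may not exceed the scatter, and there is a fair chance that the assay again reports only a limit. For compound 4 the estimate in this assay is 70 ug/mL, with a range from 20 ug/mL to 150 ug/mL.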

Compound 4, solubility: 69 ug/mL
Beside the measured number, compound 4's estimate is 1.0-fold (0.01 log units) above it; the range from low to high includes it.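

Among these compounds, compound 4 is the first compound in the set to give a number rather than a limit in this assay, so acetyl on an amine nitrogen in a ring yields the first reading that can serve as a reference for later changes at this position. Acetyl in place of hydrogen at this nitrogen gives an at least 1.4-fold lower number from compound 1 to compound 4 (0.16 log units; that floor lies within the scatter), so the data fix only a floor for the change, and that floor does not establish a drop beyond the usual variation between repeats. The upper size of the step remains unknown, since the reading for compound 1 is a limit of the assay and not a number, and the set offers no other number to compare with compound 4: the limit of > 100 ug/mL in this assay, at which 3 of the 4 values shown sit.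

As far as these compounds go, it remains open whether the result belongs to acetyl in particular or would follow from any group on this nitrogen. A plain methyl, a longer acyl chain or a chain ending in a carboxylic acid at the same nitrogen would help separate these two readings.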